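Swapping the Acetylphenyl Arm for a Methylindole

The source may hold more compounds than are shown below. What is called first, only, known or untested is meant among the compounds shown, and "the series" means these compounds.

Measured in a functional assay on MCF7 cells (Homo sapiens) for inhibition, read by CCK-8 assay, with a stated time of 48 h; a lower number here means a stronger inhibitor, a higher number a weaker inhibitor:
- compound 1, `COc1cc(-c2ccnc3cc(-c4ccc(C(C)=O)cc4)nn23)cc(OC)c1OC`: 5230 nM
- compound 2, `COc1cc(-c2ccnc3cc(-c4ccc(-c5cnn(C)c5)cc4)nn23)cc(OC)c1OC`: 274 nM
- compound 3, `CCOC(=O)c1ccc(-c2cc3nccc(-c4cc(OC)c(OC)c(OC)c4)n3n2)cc1`: > 10000 nM (a limit of the assay, not a number)

Among the two numbers known, compound 1 has the highest, so it is the weaker of the two measured inhibitors. Compound 4, `COc1cc(-c2ccnc3cc(-c4ccc5c(ccn5C)c4)nn23)cc(OC)c1OC`, has not yet been measured. It differs from compound 1 in one place: 1-methyl-1H-indol-5-yl in place of 4-acetylphenyl on an aromatic carbon.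

Two measured steps change the same arm of the shared core. Replacing acetyl by an aromatic heterocycle gave a 19-fold lower number from compound 1 to compound 2 (1.28 log units; beyond the scatter). Replacing that heterocycle by an ester gave an at least 36-fold higher number from compound 2 to compound 3 (1.56 log units; beyond the scatter), though compound 3 only reaches (the limit of > 10000 nM in this assay, at which 1 of the 3 values shown sits). An aromatic ring in that position thus gave the better number, a carbonyl-bearing group the worse one. Compound 4 carries a fused aromatic ring without a carbonyl, so a step in the direction of compound 2 is expected, perhaps somewhat smaller: an 8.7-fold lower number from compound 1 to compound 4 (0.94 log units; beyond the scatter). The estimate for compound 4 in this assay is 600 nM, with a likely range of 150 nM to 2500 nM.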

Compound 4, half-maximal inhibitory concentration: 3 nM
Compound 4: middle estimate off by 200-fold (2.30 log units), on the high side; the measured number lies below the stated range.
By their numbers in this assay, from the lowest: compound 4; then compound 2; then compound 1. At a limit, above all of these: compound 3.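

In this assay, for the compounds shown here, the exchange of arms gives a 1700-fold lower number from compound 1 to compound 4 (3.24 log units; beyond the scatter) and so shows that this position can carry far more of a gain than the earlier compounds revealed. Removing the carbonyl cannot be the whole story, since compound 2 and compound 4 both lack it, yet compound 2 stands at 274 nM while compound 4 stands at 3 nM and holds the lowest number of the set. What matters here therefore includes the shape of the aromatic group itself, a fused pair of rings rather than a phenyl ring with a substituent, though nothing measured here explains the size of this step.

As far as these compounds go, whether the methyl on the indole nitrogen is needed remains open, and the unmethylated indole with its ring hydrogen would test that. Also open, from the compounds shown here alone, is whether a fused ring such as benzofuran, with oxygen in place of that nitrogen, would serve equally well.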